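Swapping a methylpyridinyl for a methylphenyl on the piperidine

The source may hold more compounds than are shown below. What is called first, only, known or untested is meant among the compounds shown, and "the series" means these compounds.

Compound 1 `CCc1cccc(NC(=O)CN2CCN(c3ccccn3)CC2)c1`, compound 2 `O=C(CN1CCN(c2ccccn2)CC1)Nc1cccnc1` and compound 3 `Cc1ccc(C2CCN(CC(=O)Nc3cccc(C)c3)CC2)nc1` share an amide-linked aminoacetyl motif. In an assay on cells for antagonist activity at D(4) dopamine receptor (Homo sapiens), read by luminescence and beta-arrestin recruitment, with a stated time of 90 min (a lower number here means a stronger inhibitor, a higher number a weaker inhibitor), compound 1 gives 370 nM, and compound 2 gives 25800 nM, a step of a 70-fold higher number from compound 1 to compound 2 (1.84 log units; beyond the scatter). Compound 3 gives 394 nM in this assay, which sits alongside compound 1 within the scatter, while compound 2 gives a much higher number than compound 3.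

Compound 4 `Cc1ccc(C2CCN(CC(=O)Nc3cccc(C)c3)CC2)cc1` differs from compound 3 by a single change: 4-methylphenyl in place of 5-methylpyridin-2-yl on a saturated ring carbon. Within the data shown here, the one measured step, from compound 1 to compound 2, concerns the aryl group on the amide-type nitrogen, where the ring nitrogen enters together with the loss of the ethyl group, and it is large. Among the measured compounds shown here, that step sits at a different place from the change in compound 4, so it bears on it only loosely; no measured pair tests the ring on the saturated carbon. On that basis, the step from compound 3 to compound 4 is expected to be small, a 1.3-fold lower number from compound 3 to compound 4 (0.12 log units; within the scatter), with a slight lean toward a lower number. Compound 4 is therefore estimated at 300 nM in this assay, with a range of 100 nM to 1000 nM.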

Compound 4, half-maximal inhibitory concentration: 7350 nM
Estimate against measurement, compound 4: 25-fold (1.39 log units) below; measured number outside the range, above it.
By their numbers in this assay, from the lowest: compounds 1 and 3 (each within the scatter of the next); then compound 4; then compound 2.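

Among these compounds, the first pair to test the aromatic ring on the saturated ring carbon shows that this place is sensitive in this assay: a 19-fold higher number from compound 3 to compound 4 (1.27 log units; beyond the scatter), with 4-methylphenyl in place of 5-methylpyridin-2-yl. Both groups are six-membered aromatic rings carrying a methyl group, and in this large step a ring nitrogen leaves. In a 70-fold higher number from compound 1 to compound 2 (1.84 log units; beyond the scatter) a higher number came with a ring nitrogen entering at the amide-type nitrogen, together with the loss of the ethyl group, and the two places do not share one direction for a ring nitrogen. Nothing available here accounts for the size of the step from compound 3 to compound 4.

The compounds shown leave open whether other ring groups on the saturated ring carbon, such as pyrimidin-2-yl or pyridin-3-yl, stay close to compound 3 or move toward compound 4. They also leave open what the methyl group contributes to the 5-methylpyridin-2-yl group, which a plain pyridin-2-yl or a 5-chloropyridin-2-yl group at the same place would address.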